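Notes on the aryl-oxygen substituent series

A few compounds are considered here, and "the series" means these few. Any claim that something is new, unique, unknown or untested is made for them only; others in the source may bear on it.

Measured so far in a functional assay on DLD-1 cells (Homo sapiens) for cytotoxicity, with a stated time of 48 h; on this read-out lower numbers stand for stronger inhibition and higher numbers for weaker inhibition:
compound 1, `CCOc1ccc2oc(/C=C/[S+](C)[O-])cc(=O)c2c1`, gives 4900 nM.
compound 3, `Cc1ccc2oc(/C=C/[S+](C)[O-])cc(=O)c2c1`, gives 7000 nM.
compound 2, `CC(=O)Oc1ccc2oc(/C=C/[S+](C)[O-])cc(=O)c2c1`, gives only a limit of the assay, > 10000 nM.

Compound 2 thus stands at the weak end of the numbers shown, sitting on the limit (the limit of > 10000 nM in this assay, at which 1 of the 3 values shown sits), and no number is known for it. Compound 4, `CCCOc1ccc2oc(/C=C/[S+](C)[O-])cc(=O)c2c1`, differs from compound 2 as follows: propyl in place of acetyl on an oxygen on an aromatic ring. Among the compounds with values here, two measured steps bear on this change, an at least 2.0-fold higher number from compound 1 to compound 2 (0.30 log units; that floor lies within the scatter) and an at least 1.4-fold lower number from compound 2 to compound 3 (0.15 log units; that floor lies within the scatter); both run from compound 2 towards lower numbers when the acetyl is exchanged, although each is only a floor that lies within the scatter. Compound 4 carries propyl on an oxygen on an aromatic ring, the closest match being compound 1, whose ethoxy gives 4900 nM. The expected step is therefore an at least 2.2-fold lower number from compound 2 to compound 4 (0.34 log units; beyond the scatter), downward. Compound 4 is estimated at 4500 nM, with a range from 2000 nM to 12000 nM.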

Compound 4, half-maximal inhibitory concentration: 6200 nM
Compound 4: the middle estimate sits 1.4-fold (0.14 log units) below what was measured; the measured number falls inside the stated range.
By their numbers in this assay, from the lowest: compounds 1, 4 and 3 (each within the scatter of the next). At a limit, above all of these: compound 2.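

In this assay, propyl on this oxygen cannot be told apart from ethyl (a 1.3-fold higher number from compound 1 to compound 4 (0.10 log units; within the scatter)), and propoxy on the aromatic carbon cannot be told apart from methyl (a 1.1-fold lower number from compound 3 to compound 4 (0.05 log units; within the scatter)), so compounds 1, 3 and 4 form one band with no trend along the chain. Propyl in place of acetyl gives only a floor that lies within the scatter (an at least 1.6-fold lower number from compound 2 to compound 4 (0.20 log units; that floor lies within the scatter)), so a second ether does not yet set the acetoxy compound apart by a real margin. Compound 2 remains a limit of the assay and not a number: the limit of > 10000 nM in this assay, at which 1 of the 4 values shown sits.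

From the compounds shown here alone, whether a longer chain such as hexyl on this oxygen would leave the band stays open. So does the effect of a free hydroxyl here, or of an amine or a carboxylic acid at the end of the chain.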